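This account rests on a few compounds, and the source may have more. Where it says the series, first, only, none or still open, it means among the compounds named here.

Measured compounds:
compound 1 `O=c1n(Cc2nc3cc(Cl)ccn3c2CCCCO)c2cnccc2n1C1CC1`
compound 2 `N#Cc1c(Cn2c(=O)n(C3CC3)c3ccncc32)nc2cc(Cl)ccn12`
compound 3 `O=c1n(Cc2nc3cc(Cl)ccn3c2CNCCO)c2cnccc2n1C1CC1`

In an ADME assay on HEp-2 cells (Homo sapiens) for cytotoxicity, read by CCK-8 assay, with a stated time of 6 days (on this read-out lower numbers stand for higher toxicity in this test and higher numbers for lower toxicity in this test), compound 1 sits at a limit of the assay, > 100000 nM. Compound 2 gives 22500 nM in this assay. Compound 3 likewise sits at a limit, > 100000 nM, so that two of the three values shown fall at the same point, namely (the limit of > 100000 nM in this assay, at which 2 of the 3 values shown sit). Within the data shown here, compound 3 therefore stands at the low-toxicity end of what has been measured, together with compound 1, while compound 2 is the one compound with a number.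

Compound 4 `CS(=O)(=O)c1ccc(-c2c(Cn3c(=O)n(C4CC4)c4ccncc43)nc3cc(Cl)ccn23)cc1` has not yet been measured. It differs from compound 3 in one place: 4-(methylsulfonyl)phenyl in place of ((2-hydroxyethyl)amino)methyl on an aromatic carbon. Of the measured steps, the closest is an at least 4.4-fold higher number from compound 2 to compound 3 (0.64 log units; beyond the scatter), a change at the same aromatic carbon, and an at least 4.4-fold lower number from compound 1 to compound 2 (0.64 log units; beyond the scatter) points the same way; the step that the two limits leave unreadable from compound 1 to compound 3 cannot be read. A group entering at this carbon that is not a hydroxyalkyl or aminoalkyl chain has so far gone with a lower number, and a step of that kind is expected here: an at least 3.3-fold lower number from compound 3 to compound 4 (0.52 log units; beyond the scatter). Compound 4 is estimated to give 30000 nM in this assay, within 8000 nM to 100000 nM.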

Compound 4, half-maximal cytotoxic concentration: > 100000 nM
Compound 4: a limit, no number (the forecaster's own chance of this, stated with the estimate: 35%); at least 3.3-fold (0.52 log units) between middle value and limit.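

In this assay, 4-(methylsulfonyl)phenyl in place of cyano on this aromatic carbon gives an at least 4.4-fold higher number from compound 2 to compound 4 (0.64 log units; beyond the scatter), so a group without a hydroxyalkyl or aminoalkyl chain, here with an aromatic ring of carbon only and no hydrogen-bond donors, can also go with a higher number than cyano. Compound 2, the cyano compound, remains the only one of the four with a number, and the others share a single point: the limit of > 100000 nM in this assay, at which 3 of the 4 values shown sit. The steps joining compound 4 to compound 1 and to compound 3 cannot be read, as each has a limit at both ends.

From the compounds shown here alone, how compound 1, compound 3 and compound 4 rank against one another stays open. Going by these compounds, it is also open whether a plain phenyl, a carboxylic acid or a methyl on this carbon would give a number, as cyano does.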